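A few compounds are considered here, and "the series" means these few. Any claim that something is new, unique, unknown or untested is made for them only; others in the source may bear on it.

Working notes on the amide series.

Compound 1, `CCN(Cc1cccs1)C(=O)COc1ccc(C)cc1`, is the reference point: in an assay on HEK293 cells for agonist activity at transient receptor potential cation channel subfamily M member 8 (Homo sapiens), read by fluorescence and calcium flux, with a stated time of 15 min (on this read-out higher numbers stand for an effect only at larger amounts of compound and lower numbers for an effect already at smaller amounts), compound 1 gives 8 nM. Compound 2, `CCN(C(=O)COc1ccc(C)cc1)C(C)c1cccs1`, carries a 1-(thiophen-2-yl)ethyl group on the amide-type nitrogen, and in this assay compound 2 is reported as "not active" (no number reported), so no number can be set against it and its standing can only be described as without a measurable effect in this read-out.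

Compound 3, `CCN(Cc1cccnc1)C(=O)COc1ccc(C)cc1`, has not been measured. Against compound 2 the change is (pyridin-3-yl)methyl in place of 1-(thiophen-2-yl)ethyl on an amide-type nitrogen. Within the data shown here, no measured step covers this pair, so the size of the step in this assay cannot be read from existing data; the expectation is for a large move towards an effect at smaller amounts, well beyond the usual scatter, because compound 1 gives 8 nM with an unbranched methylene on the same nitrogen.

Compound 3 is therefore expected to give about 60 nM in this assay, estimated within 8 nM to 600 nM.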

Compound 3, half-maximal effective concentration: 15400 nM
For compound 3 the middle estimate is 260-fold (2.41 log units) below the measured one; measured number outside the range, above it.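

Keeping the unbranched methylene on the amide-type nitrogen does not by itself preserve the effect: with pyridin-3-yl in place of thiophen-2-yl on that saturated chain carbon, this assay shows a 1900-fold higher number from compound 1 to compound 3 (3.28 log units; beyond the scatter). The thiophen-2-yl group of compound 1 therefore matters at this place as much as the chain carbon that carries it, a point that compound 2 alone could not show, as it changes the chain carbon and keeps the thiophen-2-yl group. Steps involving compound 2 cannot be read, as it has no number.

Going by these compounds, whether a phenyl or a furan-2-yl group on the same saturated chain carbon would stay near compound 1 or fall towards compound 3 remains open. Nothing at hand accounts for the size of this step.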